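The compounds below may be only part of what the source reports. "The series", "measured", "known", "first", "only" and "open" are said of these compounds alone.

Working notes on the series. In an in vitro ADME assay on microsomes from liver (Rattus norvegicus) for metabolic stability, tested at 2 uM (a higher number here means that the compound lasts longer, a lower number that the compound disappears faster), compound 1 `O=C(O)C#Cc1ccc(NC(=O)CSc2nnnn2-c2ccc(C3CC3)cc2Cl)c(Cl)c1` gives 0.333 h, and compound 2 `CC(C)(C#Cc1ccc(NC(=O)CSc2nnnn2-c2ccc(C3CC3)cc2Cl)c(Cl)c1)OCC(=O)O` gives 0.483 h. Within the data shown here, compound 2 therefore stands within the scatter of compound 1, the only other measured compound.

Compound 3 `CC(C)(C#Cc1ccc(NC(=O)CSc2nnnn2-c2ccc(C3CC3)cc2Cl)c(Cl)c1)NCC(=O)O` has not yet been measured. It differs from compound 2 as follows: (carboxymethyl)amino in place of carboxymethoxy on a saturated chain carbon bound to two saturated chain carbons and a triple-bonded carbon. In words, this is (carboxymethyl)amino in place of carboxymethoxy on a saturated chain carbon bound to two saturated chain carbons and a triple-bonded carbon.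

Among the measured compounds shown here, no measured step makes this exchange. The nearest evidence is a 1.5-fold higher number from compound 1 to compound 2 (0.16 log units; within the scatter), where 1-(carboxymethoxy)-1-methylethyl takes the place of carboxy on a triple-bonded carbon, and that step is small. In this assay no step beyond the scatter is therefore expected, and the expected step is a 1.1-fold lower number from compound 2 to compound 3 (0.03 log units; within the scatter). For compound 3 the estimated half-life is 0.45 h, with an expected range of 0.2 h to 1 h.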

Compound 3, half-life: 1.17 h
The estimate for compound 3 lay 2.6-fold (0.41 log units) below the measured number; the whole stated range lies below it.
By their numbers in this assay, from the lowest: compounds 1 and 2 (each within the scatter of the next); then compound 3.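

In this assay this position responds to the exchange itself: (carboxymethyl)amino in place of carboxymethoxy gives a 2.4-fold higher number from compound 2 to compound 3 (0.38 log units; beyond the scatter), although the count stays at 5 heavy atoms and the computed difference is a nitrogen entering for an oxygen, with 2 hydrogen-bond donors entering against 1 leaving. Against carboxy on a triple-bonded carbon, 1-((carboxymethyl)amino)-1-methylethyl gives a 3.5-fold higher number from compound 1 to compound 3 (0.55 log units; beyond the scatter), a step beyond the scatter, whereas 1-(carboxymethoxy)-1-methylethyl gave only a 1.5-fold higher number from compound 1 to compound 2 (0.16 log units; within the scatter), within it. Nothing measured here accounts for the difference between the two groups.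

Still open, going by these compounds, is whether a simple amine without the carboxylic acid at this saturated chain carbon would hold the longer half-life. Equally open, on these data alone, is whether a longer chain between the amine and the carboxylic acid would hold it.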